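A substituted benzyl group at the assay limit

This account rests on a few compounds, and the source may have more. Where it says the series, first, only, none or still open, it means among the compounds named here.

Compound 1 (`CC(C)(C)[C@H]1C(O)=C(C2=CS(=O)(=O)c3cc(NS(C)(=O)=O)ccc3N2)C(=O)N1Cc1ccc(F)cc1`) and compound 2 (`CC(C)(C)[C@H]1C(O)=C(C2=CS(=O)(=O)c3cc(NS(C)(=O)=O)ccc3N2)C(=O)N1Cc1ccccc1`) differ only by one fluoro on an aromatic carbon. In an ADME assay on 2209-23 cells (Homo sapiens) for cytotoxicity, read by WST assay and thymidine incorporation (a higher number here means that more compound is tolerated, a lower number that less compound is tolerated), compound 1 gives > 50000 nM as a limit of the assay and not a number. Compound 2 gives > 50000 nM as a limit too, so it has no number of its own. What is known so far is the limit of > 50000 nM in this assay, at which 2 of the 2 values shown sit, and no more.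

Compound 3 (`COc1cc(CN2C(=O)C(C3=CS(=O)(=O)c4cc(NS(C)(=O)=O)ccc4N3)=C(O)[C@@H]2C(C)(C)C)ccc1F`) carries 4-fluoro-3-methoxyphenyl in place of phenyl on a saturated chain carbon bound to an amide-type nitrogen in a ring. Among the measured compounds shown here, the only measured step that bears on this is a step that the two limits leave unreadable from compound 1 to compound 2 and it gives no size to carry over. No step beyond the scatter is therefore expected in this assay and no direction can be named. The estimate means a number no higher from compound 2 to compound 3 (the limit leaves the size open) as the expected change. Compound 3 is expected at 50000 nM with an estimated range from 25000 nM to 100000 nM. Once measured, compound 3 may again give only a limit.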

Compound 3, half-maximal cytotoxic concentration: > 50000 nM
Compound 3 gave a limit, no number; the forecaster's own chance of this, stated with the estimate: 85%; the middle value lies on the limit itself.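

Among the compounds shown here, no step among compound 1, compound 2 and compound 3 can be read in this assay and each gives only a limit of the assay: the limit of > 50000 nM in this assay, at which 3 of the 3 values shown sit.

The compounds shown leave open at which concentration any of the three becomes toxic to these cells, and whether the fluoro or the 4-fluoro-3-methoxyphenyl group changes that concentration at all.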